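The source may hold more compounds than are shown below. What is called first, only, known or untested is meant among the compounds shown, and "the series" means these compounds.

Working notes on the series

Compound 1 `CC(C)NC(=N)c1ccc2oc(-c3cccc(OCCCOc4ccccc4)c3)cc2c1` and compound 2 `CC(C)NC(=N)c1ccc2oc(-c3cccc(OCCCCOc4ccccc4)c3)cc2c1` share one core; compound 3 `N=C(N)c1ccc2cc(-c3ccc(OCCCOc4ccccc4)cc3)oc2c1` and the as yet unmeasured compound 4 `N=C(N)c1ccc2cc(-c3ccc(OCCCCOc4ccccc4)cc3)oc2c1` share another. The difference between the two cores is not broken down here. In an ADME assay on L6 cells (Rattus norvegicus) for cytotoxicity, read by resazurin assay, with a stated time of 70 h (on this read-out lower numbers stand for stronger inhibition and higher numbers for weaker inhibition), compound 1 gives 26500 nM, compound 2 gives 36500 nM and compound 3 gives 8600 nM. Compound 3 stands lowest of the three measured numbers, with compound 1 nearest and compound 2 furthest.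

The change from compound 1 to compound 2 is phenoxymethyl in place of phenoxy on a saturated chain carbon, three bonds along the chain from an oxygen on an aromatic ring, and in this assay it made a 1.4-fold higher number from compound 1 to compound 2 (0.14 log units; within the scatter). The change from compound 3 to compound 4 is phenoxymethyl in place of phenoxy on a saturated chain carbon, three bonds along the chain from an oxygen on an aromatic ring, the same change at the same place on the other core. It occurs twice among the compounds shown.

Going by the values given here, because the one measured instance, a 1.4-fold higher number from compound 1 to compound 2 (0.14 log units; within the scatter), stayed within the scatter, compound 4 is expected to sit close to compound 3, with an estimated step of a 1.3-fold higher number from compound 3 to compound 4 (0.11 log units; within the scatter). In this assay compound 4 is therefore estimated at 11000 nM, expected to lie between 5500 nM and 22000 nM.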

Compound 4, half-maximal inhibitory concentration: 14100 nM
Compound 4: middle estimate off by 1.3-fold (0.11 log units), on the low side; measured number inside the range.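

In this assay, the change from phenoxy to phenoxymethyl on a saturated chain carbon, three bonds along the chain from an oxygen on an aromatic ring, gives a 1.6-fold higher number from compound 3 to compound 4 (0.21 log units; within the scatter). Set beside the earlier step, the change carries from one core to the other with no difference that can be told from the scatter: the same change on two cores in this assay, a 1.4-fold higher number (0.14 log units; within the scatter) from compound 1 to compound 2 and a 1.6-fold higher number (0.21 log units; within the scatter) from compound 3 to compound 4, 1.2-fold (0.08 log units) apart, within the scatter of two such steps This shows that on these two cores the change leaves the number within the scatter, but with only two pairs it does not establish a fixed size for the step, nor does it show how the change would behave on any other core.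

From the compounds shown here alone, it remains open whether the steps stay this small with a longer chain, or with an amine or a carboxylic acid in place of the terminal phenoxy group. Going by these compounds, how the difference between the two cores itself bears on this read-out also remains open.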